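Trading a Methyl for Hydrogen: What Compound 4 Should Show

This account rests on a few compounds, and the source may have more. Where it says the series, first, only, none or still open, it means among the compounds named here.

Measured compounds in an ADME assay on RAW264.7 cells (Mus musculus) for cytotoxicity, read by MTT assay, with a stated time of 24 h, tested at 10 ug/mL; a lower number here means a stronger effect, a higher number a weaker effect of the compound at the concentration tested:
compound 1 `COc1ccc(/C=C/C(=O)c2ccc(OC)c(OC)c2)cc1`, 73.9%
compound 2 `COc1ccc(/C=C/C(=O)c2ccc(OC)c(OC)c2)cc1OC`, 60.4%
compound 3 `COc1ccc(/C=C/C(=O)c2ccc(OC)c(OC)c2)cc1O`, 73.5%

Compound 1 gives the highest of the three numbers; compound 3 sits within the scatter of it, while compound 2 lies a number 13.5 percentage points lower from compound 1 to compound 2 (beyond the scatter). Compound 4 `COc1ccc(/C=C/C(=O)c2ccc(O)c(OC)c2)cc1` differs from compound 1 by hydrogen in place of methyl on an oxygen on an aromatic ring. Among the compounds with values here, the single measured step of the same kind is a number 13.1 percentage points higher from compound 2 to compound 3 (beyond the scatter), a modest rise. The step of a number 0.4 percentage points lower from compound 1 to compound 3 (within the scatter) shows that a hydroxy in place of hydrogen left the number where it was. On this basis a small rise, or no change beyond the scatter, is expected in this assay, a number 4.1 percentage points higher from compound 1 to compound 4 (within the scatter). Compound 4 is estimated at 78%, within 64% to 92%.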

Compound 4, a percentage reported as activity, at one concentration (the size of the read-out at that concentration, not a potency): 62.3%
The estimate for compound 4 lay 15.7 percentage points above the measured number, and the stated range ends above it.
By their numbers in this assay, from the lowest: compounds 2 and 4 (each within the scatter of the next); then compounds 3 and 1 (each within the scatter of the next).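

In this assay, hydrogen in place of methyl on an oxygen on an aromatic ring gave a number 11.6 percentage points lower from compound 1 to compound 4 (beyond the scatter), so this change can lower the number as well as raise it. Its direction therefore differs with the core that carries it: the same change on two cores in this assay, a number 13.1 percentage points higher (beyond the scatter) from compound 2 to compound 3 and a number 11.6 percentage points lower (beyond the scatter) from compound 1 to compound 4, 24.7 percentage points apart, beyond the scatter of two such steps.

The compounds shown leave open whether compound 4 owes its lower number to the hydroxy itself or to the loss of the methyl. They also leave open how an amine or a longer chain such as ethoxy would read at this place.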